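Removing One Ring Nitrogen: Expected Clearance of Compound 3

The source may report more compounds than this note shows. Statements on the series, on what has been measured and on what is new or still open speak of the compounds shown alone.

This account follows a single change made to compound 2 `CC(C)n1cc(-c2ccnc3[nH]c(C4CCN(CC(=O)N(C)C)CC4)cc23)cnc1=O` and asks what it may do in an ADME assay (Rattus norvegicus, strain Han-wistar) for pharmacokinetics, at a dose of 1.5 umol/kg by the intravenous route; a lower number here means slower removal, a higher number faster removal of the compound. Going by the values given here, of the two compounds measured so far, compound 2 gives 72 mL/min/kg, the higher of the two numbers; its nearest neighbour is compound 1 `COc1cc(F)ccc1-c1ccnc2[nH]c(C3CCN(CC(=O)N(C)C)CC3)cc12`, which in this assay gives 51 mL/min/kg. Among the compounds with values here, the only measured step, a 1.4-fold higher number from compound 1 to compound 2 (0.15 log units; within the scatter), lies within the scatter and concerns a different change, so it offers little guidance for what comes next.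

Compound 3 `CC(C)n1cc(-c2ccnc3[nH]c(C4CCN(CC(=O)N(C)C)CC4)cc23)ccc1=O` differs from compound 2 in one place: a group of 10 heavy atoms (8 carbon, 1 nitrogen, 1 oxygen; one six-membered aromatic ring with 1 hetero atom) in place of a group of 10 heavy atoms (7 carbon, 2 nitrogen, 1 oxygen; one six-membered aromatic ring with 2 hetero atoms), on an aromatic carbon. The group that leaves carries two hetero atoms in its six-membered aromatic ring, the group that enters only one. Within the data shown here, no measured pair here has this kind of change, so nothing in the data points to a step beyond the scatter in this assay. Compound 3 is therefore expected to show a clearance close to that of compound 2, the step of a 1.0-fold higher number from compound 2 to compound 3 (0.02 log units; within the scatter) being the estimate. The expected value for compound 3 is 75 mL/min/kg, with a range from 45 mL/min/kg to 120 mL/min/kg.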

Compound 3, clearance: 77 mL/min/kg
Compound 3: the middle estimate sits 1.0-fold (0.01 log units) below what was measured; the range from low to high includes it.
By their numbers in this assay, from the lowest: compounds 1, 2 and 3 (each within the scatter of the next).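

In this assay, putting a six-membered aromatic ring with 1 hetero atom in place of one with 2 hetero atoms, on this aromatic carbon opposite the ring nitrogen, gives a 1.1-fold higher number from compound 2 to compound 3 (0.03 log units; within the scatter) for the step, which shows that this single ring atom can be exchanged here without the read-out leaving the scatter. Set against the six-membered aromatic ring of carbon only, the same entering group gives a 1.5-fold higher number from compound 1 to compound 3 (0.18 log units; within the scatter) in this comparison, so all the groups shown at this position, whether their rings hold no hetero atom, 1 hetero atom or 2 hetero atoms, stand within the scatter of one another. Nothing available bears on what lies behind these numbers.

From the compounds shown here alone, all three groups are six-membered aromatic rings, so it stays open whether an amine or a carboxylic acid carried on such a ring at this position would take this assay beyond the scatter. Going by these compounds, it also stays open whether this exchange of a ring nitrogen for carbon would give as small a step with a different group on the shared core.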